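Two Parallel Chain Truncations in an Antiproliferative Series

This account rests on a few compounds, and the source may have more. Where it says the series, first, only, none or still open, it means among the compounds named here.

Compound 1 `COc1ccc(Nc2nc(NCCCO)c3ccccc3n2)cc1`: 17100 nM
Compound 2 `CNc1nc(Nc2ccc(OC)cc2)nc2ccccc12`: 17500 nM
Compound 3 `COc1ccc(N(C)c2nc(NCCCO)c3ccccc3n2)cc1`: 30800 nM

Of the compounds shown here, three have been measured in a functional assay on KBVIN cells (Homo sapiens) for antiproliferative activity, read by sulforhodamine B assay, with a stated time of 48 h; a lower number here means a stronger inhibitor of growth, a higher number a weaker inhibitor of growth. Compound 1 gives 17100 nM, compound 2 gives 17500 nM and compound 3 gives 30800 nM. Compound 2 differs from compound 1 by hydrogen in place of 2-hydroxyethyl on a saturated chain carbon bound to a nitrogen on an aromatic ring, and this change made a 1.0-fold higher number from compound 1 to compound 2 (0.01 log units; within the scatter). Compound 3 differs from compound 1 by methyl in place of hydrogen on a nitrogen on an aromatic ring, which gave a 1.8-fold higher number from compound 1 to compound 3 (0.26 log units; within the scatter). All three values lie within the scatter of one another.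

Compound 4 `CNc1nc(N(C)c2ccc(OC)cc2)nc2ccccc12` has not yet been measured. It differs from compound 3 by hydrogen in place of 2-hydroxyethyl on a saturated chain carbon bound to a nitrogen on an aromatic ring, the same change as from compound 1 to compound 2, made on a core that carries the difference described by methyl in place of hydrogen on a nitrogen on an aromatic ring; the place of the change reads the same in both cases. The step from compound 3 to compound 4 is therefore expected to be a 1.0-fold higher number from compound 3 to compound 4 (0.00 log units; within the scatter) in this assay, resting on the earlier 1.0-fold higher number from compound 1 to compound 2 (0.01 log units; within the scatter). For compound 4 the estimate is 31000 nM. For compound 4 the expected range runs from 13000 nM to 75000 nM.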

Compound 4, concentration for 50% growth inhibition: 22900 nM
Compound 4: the middle estimate sits 1.4-fold (0.13 log units) above what was measured; the range from low to high includes it.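

In this assay, 3-hydroxypropyl to methyl on the core that carries the methyl on the nitrogen gave a 1.3-fold lower number from compound 3 to compound 4 (0.13 log units; within the scatter), and this step agrees with its counterpart on the core of compound 1: the same change on two cores in this assay, a 1.0-fold higher number (0.01 log units; within the scatter) from compound 1 to compound 2 and a 1.3-fold lower number (0.13 log units; within the scatter) from compound 3 to compound 4, 1.4-fold (0.14 log units) apart, within the scatter of two such steps

Methyl in place of hydrogen on a nitrogen on an aromatic ring gave a 1.3-fold higher number from compound 2 to compound 4 (0.12 log units; within the scatter), and this step agrees with its earlier counterpart in the same way: the same change on two cores in this assay, a 1.8-fold higher number (0.26 log units; within the scatter) from compound 1 to compound 3 and a 1.3-fold higher number (0.12 log units; within the scatter) from compound 2 to compound 4, 1.4-fold (0.14 log units) apart, within the scatter of two such steps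

Among these compounds, both changes therefore carried from one core to the other without a detectable difference, but every step here lies within the scatter, so the four compounds show only that neither change separates the values on either core, not that a step of real size would carry over in the same way.

The compounds shown leave open whether a longer chain, or a chain ending in an amine or a carboxylic acid, would give a step beyond the scatter. They also leave open how a group larger than methyl, such as ethyl, would behave on that nitrogen.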